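The source may hold more compounds than are shown below. What is called first, only, known or untested is meant among the compounds shown, and "the series" means these compounds.

In a functional assay on HepG2 cells (Homo sapiens), read by MTT assay, with a stated time of 48 h (a higher number here means a weaker inhibitor, a lower number a stronger inhibitor), compound 3 `CCn1c(C(=O)N(CCC#N)CCC#N)ccc1C(CC)(CC)c1ccc(OCC(O)C(C)(C)C)c(C)c1` gives 42000 nM and compound 2 `CCn1c(C(=O)NCC(OC)OC)ccc1C(CC)(CC)c1ccc(OCC(O)C(C)(C)C)c(C)c1` gives 23200 nM. These two values sit within the scatter of each other, as a 1.8-fold higher number from compound 2 to compound 3 (0.26 log units; within the scatter) shows. Compound 1 `C#CCNC(=O)c1ccc(C(CC)(CC)c2ccc(OCC(O)C(C)(C)C)c(C)c2)n1CC` returns only a limit, > 50000 nM.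

Compound 4 `CC[C@@H](C)[C@H](NC(=O)c1ccc(C(CC)(CC)c2ccc(OCC(O)C(C)(C)C)c(C)c2)n1CC)C(=O)O` carries (1-carboxy-2-methylbutyl)amino on the carbonyl carbon: a group of 9 heavy atoms (6 carbon, 1 nitrogen, 2 oxygen; no ring) in place of a group of 9 heavy atoms (6 carbon, 3 nitrogen; no ring), on a carbonyl carbon.

Among the compounds with values here, three measured steps bear on this change, all of them swaps at the same carbonyl carbon. The first, an at least 2.1-fold lower number from compound 1 to compound 2 (0.33 log units; beyond the scatter), goes beyond the scatter but rests on the limit. The second, an at least 1.1-fold lower number from compound 1 to compound 3 (0.07 log units; that floor lies within the scatter), has a floor within the scatter. The third is the step from compound 2 already given. Within the data shown here, no measured compound carries a carboxy group, so these steps offer only an indirect guide.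

With compound 3 at 42000 nM, no shift beyond the scatter is expected in this assay. For compound 4, a report of only a limit remains quite possible. The expected step is a 1.1-fold lower number from compound 3 to compound 4 (0.02 log units; within the scatter). For compound 4 the estimated value is 40000 nM, with an expected range of 15000 nM to 90000 nM.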

Compound 4, half-maximal inhibitory concentration: 127 nM
Estimate against measurement, compound 4: 310-fold (2.50 log units) above, outside the stated range (below it).
By their numbers in this assay, from the lowest: compound 4; then compounds 2 and 3 (each within the scatter of the next). At a limit, above all of these: compound 1.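

In this assay the substituent on this carbonyl carbon proves able to move the number far more than the earlier swaps there, which gave modest steps at most, had indicated. With (1-carboxy-2-methylbutyl)amino in place, the change reads as a 330-fold lower number from compound 3 to compound 4 (2.52 log units; beyond the scatter), as a 180-fold lower number from compound 2 to compound 4 (2.26 log units; beyond the scatter) and as an at least 390-fold lower number from compound 1 to compound 4 (2.59 log units; beyond the scatter), so all three earlier amide groups fall well short of the new one. Compound 1 is reported only as a limit, so the last of these steps is a floor: the limit of > 50000 nM in this assay, at which 1 of the 4 values shown sits.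

The compounds shown do not separate the carboxy group of compound 4 from its branched chain or from its two defined stereocentres. A methyl ester, a primary amide or a shorter carboxymethyl chain on the same amide-type nitrogen would bear on that question.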